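A Fluorine Enters the Core of Compound 2

The source may report more compounds than this note shows. Statements on the series, on what has been measured and on what is new or still open speak of the compounds shown alone.

Measured so far:
Compound 1, `COc1cc(C(=O)n2c(C)c(CC(=O)O)c3ccccc32)ccc1OC[C@@H]1CN(C)c2ccccc2O1`: 340 nM
Compound 2, `Cc1cc(C(=O)n2c(C)c(CC(=O)O)c3ccccc32)c(C)cc1OC[C@@H]1CN(C)c2ccccc2O1`: 360 nM

In an assay on CHO cells for displacement of a labelled ligand from prostaglandin D2 receptor (Mus musculus), read by scintillation counting, with a stated time of 20 min (a lower number here means a stronger inhibitor, a higher number a weaker inhibitor), compound 2 gives 360 nM. That is the higher of the two numbers, but compound 1 gives 340 nM, and the gap between the two is within the scatter, so nothing separates them. Compound 3, `Cc1cc(C(=O)n2c(C)c(CC(=O)O)c3cc(F)ccc32)c(C)cc1OC[C@@H]1CN(C)c2ccccc2O1`, is built from compound 2 by one change: fluoro in place of hydrogen on an aromatic carbon. Going by the values given here, no pair of measured compounds differs by this change, so there is no measured step to lean on. With only a single fluorine entering and no other change, the writer expects a step no larger than the scatter, in either direction. For compound 3 the estimate in this assay is 300 nM, with a range from 120 nM to 800 nM. That estimate amounts to an expected step of a 1.2-fold lower number from compound 2 to compound 3 (0.08 log units; within the scatter).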

Compound 3, inhibition constant: 14 nM
The estimate for compound 3 lay 21-fold (1.33 log units) above the measured number; the measured number lies below the stated range.
By their numbers in this assay, from the lowest: compound 3; then compounds 1 and 2 (each within the scatter of the next).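

In this assay, going by these compounds alone, placing fluoro on this aromatic carbon in place of hydrogen gives a 26-fold lower number from compound 2 to compound 3 (1.41 log units; beyond the scatter) and marks the first large step. Compounds 1 and 2 both carry hydrogen here, so they could not show that this position, meta to a fused ring and para to a fused ring, responds so strongly to one added heavy atom. Nothing in the material shown explains the size of this step.

Whether the gain is specific to fluoro stays open, since chloro, methyl, methoxy and nitrile at this carbon do not figure among the compounds shown. On these data alone, it is also open whether the same change would carry the same weight on compound 1, with its different substitution on the benzoyl-side ring.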